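The source may hold more compounds than are shown below. What is called first, only, known or untested is meant among the compounds shown, and "the series" means these compounds.

Measured compounds:
- compound 1 `CC1=C(C(N)=O)C(c2ccoc2)NC(=O)N1`: 1%
- compound 2 `CC1=C(C(N)=O)C(c2ccsc2)NC(=O)N1`: 2%
- compound 3 `CC1=C(c2ncc(C)o2)C(c2ccsc2)NC(=O)N1`: 34%

In an assay on membranes from CHO cells for displacement of a labelled ligand from adenosine receptor A1 (Homo sapiens), read by scintillation counting, with a stated time of 60 min, tested at 1 uM (a higher number here means more inhibition at the concentration tested (going by the name of the read-out), a lower number less inhibition), compound 2 gives 2%, the second highest of the three numbers. Its nearest neighbour is compound 1 with 1%; the step of a number 1 percentage points higher from compound 1 to compound 2 (within the scatter) lies within the scatter, so the two are not told apart. Among the compounds with values here, compound 3, at 34%, is the only compound that stands clearly apart: the step of a number 32 percentage points higher from compound 2 to compound 3 (beyond the scatter) is large and beyond the scatter.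

Compound 4 `CC1=C(C(=O)OC2CCC2)C(c2ccsc2)NC(=O)N1` is not yet measured. Relative to compound 2 it carries cyclobutyloxy in place of amino on a carbonyl carbon.

Within the data shown here, the one measured step at the same carbonyl carbon is the move from compound 2 to compound 3, where the whole carbamoyl was exchanged for 5-methyl-1,3-oxazol-2-yl and this assay rose sharply. Among the measured compounds shown here, the change to compound 4 keeps the carbonyl and only exchanges the amino for cyclobutyloxy, so that step is a loose guide at best; no measured pair tests a cyclobutyloxy directly. The expectation for compound 4 is therefore a modest rise, a number 10 percentage points higher from compound 2 to compound 4 (within the scatter), with a wide range, and the estimated value for compound 4 is 12% (from 0% to 40%).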

Compound 4, a percentage reported as inhibition, at one concentration (the size of the read-out at that concentration, not a potency): 40%
Compound 4: the middle estimate sits 28 percentage points below what was measured; the range from low to high includes it.
By their numbers in this assay, from the lowest: compounds 1 and 2 (each within the scatter of the next); then compounds 3 and 4 (each within the scatter of the next).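

In this assay, the carbonyl can stay in place and the read-out still moves: exchanging amino for cyclobutyloxy on the carbonyl carbon gives a number 38 percentage points higher from compound 2 to compound 4 (beyond the scatter). A large gain at this place therefore does not require replacing the whole carbamoyl, and compound 3 at 34% and compound 4 at 40% lie within the scatter of each other, despite carrying different groups there. No measured evidence on hand accounts for the step.

Going by these compounds, whether the gain depends on the cyclobutyl ring remains open; a methoxy, a longer chain such as n-butoxy, or a hydroxyl giving the carboxylic acid on the same carbonyl would address that. On these data alone, it also remains open whether cyclobutyloxy gives a similar result with furan-3-yl on the saturated ring carbon.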